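The source may report more compounds than this note shows. Statements on the series, on what has been measured and on what is new or still open speak of the compounds shown alone.

Working notes on the series, read in a functional assay on RS4-11 cells (Homo sapiens) for inhibition, read by CCK-8 assay, with a stated time of 48 h, tested at 20 uM; a higher number here means more inhibition of growth at the concentration tested, a lower number less inhibition of growth. Compound 1 (`N#C/C(=C\c1ccccc1OS(=O)(=O)c1ccc(Cl)cc1)C(=O)Nc1nnc(Cc2cccc3ccccc23)s1`) gives 68% and compound 2 (`N#C/C(=C\c1ccccc1OS(=O)(=O)c1ccc([N+](=O)[O-])cc1)C(=O)Nc1nnc(Cc2ccc(Cl)cc2)s1`) gives 66%, so these two values stand within the scatter of each other. Going by the values given here, no measured pair differing in one place is available, so the data show no size for any single change. Compound 3 (`N#C/C(=C\c1ccccc1OS(=O)(=O)c1ccc(Cl)cc1)C(=O)Nc1nnc(Cc2ccc(Cl)cc2)s1`) is still unmeasured. Relative to compound 2 it carries chloro in place of nitro on an aromatic carbon, para to a large group, with 4-nitrophenyl becoming 4-chlorophenyl: chloro in place of nitro on an aromatic carbon. Nothing measured favours a direction for this change, so no shift beyond the scatter is expected. The estimated step of no change at the digits printed from compound 2 to compound 3 (within the scatter) is therefore small. For compound 3 the expected value is 66%, with an estimated range of 52% to 80%.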

Compound 3, percent growth inhibition at one concentration: 64%
Estimate against measurement, compound 3: 2 percentage points above; the measured number falls inside the stated range.
By their numbers in this assay, from the lowest: compounds 3, 2 and 1 (each within the scatter of the next).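

Compound 3 gives the series its first comparisons of compounds differing in one place. On an aromatic carbon para to a large group, chloro in place of nitro gives a number 2 percentage points lower from compound 2 to compound 3 (within the scatter) in this assay, so this exchange, 4-nitrophenyl to 4-chlorophenyl, shows no shift that can be separated from the scatter. The second change, 4-chlorophenyl in place of naphthalen-1-yl on a saturated chain carbon bound to an aromatic carbon, gives a number 4 percentage points lower from compound 1 to compound 3 (within the scatter) and likewise has no readable effect here, though no measurement available explains either result.

From the compounds shown here alone, whether an amine or a carboxylic acid in place of chloro on that aromatic carbon would move the number beyond the scatter stays open. The same holds for a longer chain in place of the saturated chain carbon.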